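Exchanging the group on the saturated chain carbon

This account rests on a few compounds, and the source may have more. Where it says the series, first, only, none or still open, it means among the compounds named here.

In a functional assay on A549 cells (Homo sapiens) for antiproliferative activity, read by MTT assay, with a stated time of 48 h (on this read-out higher numbers stand for weaker inhibition and lower numbers for stronger inhibition), compound 1 `CC(C)=CCC[C@]1(C)/C=C/[C@@H](OC(=O)C=C(C)C)[C@](C)(O)/C=C/C(=O)/C(CN2CCCC2)=C\C1` gives 180 nM and compound 2 `CC[Si](CC)(CC)C/C1=C/C[C@](C)(CCC=C(C)C)/C=C/[C@@H](OC(=O)C=C(C)C)[C@](C)(O)/C=C/C1=O` gives 3100 nM, the higher of the two numbers and so the weaker inhibition. Compound 3 `CSC(=S)OC/C1=C/C[C@](C)(CCC=C(C)C)/C=C/[C@@H](OC(=O)C=C(C)C)[C@](C)(O)/C=C/C1=O` keeps the shared core of compound 2 and changes one group: a group of 5 heavy atoms (2 carbon, 1 oxygen, 2 sulfur; no ring) in place of a group of 7 heavy atoms (6 carbon, 1 silicon; no ring), on a saturated chain carbon bound to a double-bonded ring carbon. In words, a group of 5 heavy atoms replaces a group of 7 heavy atoms, on a saturated chain carbon bound to a double-bonded ring carbon.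

Among the compounds with values here, only one measured step bears on this place: a 17-fold higher number from compound 1 to compound 2 (1.24 log units; beyond the scatter), a large step beyond the scatter. Within the data shown here, it shows that the number can move widely with the group here, but the entering group has no measured counterpart, so the size stays uncertain. A moderate move to a lower number is expected in this assay, stopping short of compound 1. The expected step is a 2.6-fold lower number from compound 2 to compound 3 (0.41 log units; beyond the scatter). Compound 3 is estimated at 1200 nM, with an expected range of 300 nM to 4500 nM.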

Compound 3, half-maximal inhibitory concentration: 380 nM
Estimate against measurement, compound 3: 3.2-fold (0.50 log units) above; the measured number falls inside the stated range.
By their numbers in this assay, from the lowest: compound 1; then compound 3; then compound 2.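

In this assay the exchange on the saturated chain carbon bound to a double-bonded ring carbon gives an 8.2-fold lower number from compound 2 to compound 3 (0.91 log units; beyond the scatter) and so shows that a group with no ring and no nitrogen can recover most of the distance to compound 1. The remaining gap, a 2.1-fold higher number from compound 1 to compound 3 (0.32 log units; beyond the scatter) and printed as beyond the scatter, leaves compound 1, with its five-membered ring holding nitrogen, at the lowest number of the three. No measurement on hand explains these differences between the groups.

The compounds shown leave open whether the nitrogen or the ring of compound 1 goes with its lower number, and an open-chain amine such as dimethylamine at this place would separate the two. Also open, from the compounds shown here alone, is whether the sulfur atoms of compound 3 matter, which a simple acetate ester here would test.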